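The compounds below may be only part of what the source reports. "The series", "measured", "known", "first", "only" and "open" are said of these compounds alone.

Measured so far in a functional assay on BJAB cells (Homo sapiens) for antiproliferative activity, with a stated time of 4 days; a lower number here means that less compound is needed, a higher number that more compound is needed for the effect:
- compound 1 `CCSc1sc(-n2nc(C)c(Cc3ccccc3[N+](=O)[O-])c2C(=O)O)nc1-c1ccc(Cl)c(Cl)c1` gives 59000 nM
- compound 2 `COc1ccccc1-c1c(C)nn(-c2nc(-c3ccc(Cl)c(Cl)c3)c(SC(C)C)s2)c1C(=O)O` gives 14700 nM
- compound 3 `CNc1cc(-c2c(C)nn(-c3nc(-c4ccc(Cl)c(Cl)c4)c(SC(C)C)s3)c2C(=O)O)ccn1` gives 18000 nM

Compound 3 stands second highest of the three numbers in this assay; its nearest neighbour is compound 2, within the scatter, and its furthest is compound 1, beyond the scatter.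

Compound 4 `Cc1nn(-c2nc(-c3ccc(Cl)c(Cl)c3)c(SC(C)C)s2)c(C(=O)O)c1Cc1ccccc1[N+](=O)[O-]` is not yet measured. It differs from compound 3 in one place: 2-nitrobenzyl in place of 2-(methylamino)pyridin-4-yl on an aromatic carbon.

Among the measured compounds shown here, no measured step covers exactly this exchange. For the measured compounds named here, the only step in the set, a 1.2-fold higher number from compound 2 to compound 3 (0.09 log units; within the scatter), swaps one aromatic group for another and stays within the scatter, so it offers no direction for this change. Compound 1 also carries the 2-nitrobenzyl group but differs from compound 4 elsewhere; in this assay compound 1 gives 59000 nM, a higher number than compound 2 or compound 3. On that basis a higher number is expected for compound 4, with a 2.2-fold higher number from compound 3 to compound 4 (0.35 log units; beyond the scatter) as the estimated step. The estimate for compound 4 is 40000 nM, within 15000 nM to 120000 nM.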

Compound 4, half-maximal effective concentration: 20000 nM
Beside the measured number, compound 4's estimate is 2.0-fold (0.30 log units) above it; low and high end bracket the measured number.
By their numbers in this assay, from the lowest: compounds 2, 3 and 4 (each within the scatter of the next); then compound 1.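

In this assay, the aromatic carbon next to the ring atom that bears a carboxy group accepts 2-nitrobenzyl with no separable change: the exchange for 2-(methylamino)pyridin-4-yl gives a 1.1-fold higher number from compound 3 to compound 4 (0.05 log units; within the scatter), and the exchange for 2-methoxyphenyl gives a 1.4-fold higher number from compound 2 to compound 4 (0.13 log units; within the scatter). The high number of compound 1 therefore does not follow the 2-nitrobenzyl group, since methyl in place of hydrogen on the saturated chain carbon bound to sulfur gives a 3.0-fold lower number from compound 1 to compound 4 (0.47 log units; beyond the scatter). No supporting measurement accounts for either result.

Going by these compounds, whether this position stays equally tolerant with hydrogen or a saturated amine such as piperidine remains open. Also open, on these data alone, is whether a longer chain on the sulfur, such as butyl, extends the shift seen with the added methyl.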